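Shortening the side chain and changing its amine on compound 3

The compounds below may be only part of what the source reports. "The series", "measured", "known", "first", "only" and "open" are said of these compounds alone.

Of the compounds shown here, three sharing one core have been tested in a functional assay on SH-SY5Y cells (Homo sapiens) for cytotoxicity, read by MTT assay, with a stated time of 72 h; a lower number here means a stronger inhibitor, a higher number a weaker inhibitor. Compound 1 `O=C1c2c[n+]([O-])c3ccccc3c2C(=O)c2c1c1ccccc1n2CCCCN1CCNCC1` gives 1240 nM. Compound 2 `O=C1c2c[n+]([O-])c3ccccc3c2C(=O)c2c1c1ccccc1n2CCN1CCCC1` gives 520 nM. Compound 3 `CN1CCN(CCCCn2c3c(c4ccccc42)C(=O)c2c[n+]([O-])c4ccccc4c2C3=O)CC1` gives 100 nM, the lowest of the three numbers; its nearest neighbour is compound 2, and compound 1 stands furthest from it.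

Compound 4 `O=C1c2c[n+]([O-])c3ccccc3c2C(=O)c2c1c1ccccc1n2CCCN1CCC(O)CC1` is not yet measured. It differs from compound 3 in one place: 4-hydroxypiperidin-1-yl in place of (4-methylpiperazin-1-yl)methyl on a saturated chain carbon, three bonds along the chain from an aromatic nitrogen.

Two of the measured steps bear on this change. The step of a 12-fold lower number from compound 1 to compound 3 (1.09 log units; beyond the scatter) shows how much a methyl on the ring amine nitrogen alone lowers the number; compound 4 gives up that methylated ring for a ring carrying a hydroxyl, so part of that gain may be lost. The step of a 5.2-fold lower number from compound 2 to compound 3 (0.72 log units; beyond the scatter) shows that swapping one amine-bearing chain for another moves the number by a modest amount, and the step of a 2.4-fold lower number from compound 1 to compound 2 (0.38 log units; beyond the scatter) shows a similar modest effect. On balance, a rise in the number back toward compound 1 is expected, by a modest step, a 6.0-fold higher number from compound 3 to compound 4 (0.78 log units; beyond the scatter). For compound 4 the estimated value in this assay is 600 nM, with a likely range from 200 nM to 2000 nM.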

Compound 4, half-maximal inhibitory concentration: 130 nM
Compound 4: middle estimate off by 4.6-fold (0.66 log units), on the high side; measured number below the stated range.
By their numbers in this assay, from the lowest: compounds 3 and 4 (each within the scatter of the next); then compound 2; then compound 1.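

In this assay, replacing 4-(4-methylpiperazin-1-yl)butyl with 3-(4-hydroxypiperidin-1-yl)propyl gives a 1.3-fold higher number from compound 3 to compound 4 (0.11 log units; within the scatter), so among these compounds a low number does not depend on the 4-methylpiperazin-1-yl group. The earlier step from compound 1 to compound 3 tied the low number to a methyl on the ring amine, but compound 4 has no such methyl and still gives a 9.5-fold lower number from compound 1 to compound 4 (0.98 log units; beyond the scatter) and a 4.0-fold lower number from compound 2 to compound 4 (0.60 log units; beyond the scatter), so a second side chain now reaches the low end of this small series. No measured evidence here explains why these two different side chains give numbers within the scatter of each other.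

The step changes the ring and the chain length together, so the compounds shown cannot say how much each contributes, and a pair such as 3-(4-methylpiperazin-1-yl)propyl and 4-(4-hydroxypiperidin-1-yl)butyl would pull the two apart. On these data alone, it also remains open what the hydroxyl contributes, which a plain piperidin-1-yl on the same chain would test, and whether a morpholin-4-yl ring would fit the same trend.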